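The compounds below may be only part of what the source reports. "The series", "measured", "known", "first", "only" and "open" are said of these compounds alone.

Measured compounds:

Compound 1 `C#CCOc1ccc(/C=C/C(=O)c2ccc(OC)cc2)cc1` — in a functional assay on HepG2 cells (Homo sapiens) for inhibition, read by MTT assay, with a stated time of 48 h, tested at 10 uM (a higher number here means more inhibition of growth at the concentration tested, a lower number less inhibition of growth), compound 1 gives 25%.
Compound 2 `O=C(/C=C/c1ccc(OCc2cn(Cc3ccccc3Br)nn2)cc1)c1ccc(Br)cc1` — in this assay compound 2 gives 34%.
Compound 3 `O=C(/C=C/c1ccc(OCc2cn(Cc3cccc(Br)c3)nn2)cc1)c1ccc(Br)cc1` — in this assay compound 3 gives 25%.

Compound 3 stands level with compound 1 at the digits given, the two together the lowest of the three numbers; its nearest neighbour is compound 1 with no change at those digits, its furthest is compound 2, and that gap too lies within the scatter. Among the measured compounds shown here, the one step through this region of the structure, a number 9 percentage points lower from compound 2 to compound 3 (within the scatter), moves the bromine around the ring on the benzyl group and stays within the scatter.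

Compound 4 `O=C(/C=C/c1ccc(OCc2cn(Cc3ccccc3F)nn2)cc1)c1ccc(Br)cc1` is not yet measured. It differs from compound 3 by 2-fluorophenyl in place of 3-bromophenyl on a saturated chain carbon bound to an aromatic nitrogen. For the measured compounds named here, the only step that bears on this position, the move from compound 2 to compound 3, was within the scatter, and there is no step that swaps bromine for fluorine at all. The expectation for this assay is therefore a step of a number 3 percentage points higher from compound 3 to compound 4 (within the scatter), that is, none beyond the scatter. For compound 4 the estimate is 28%, with a range from 15% to 42%.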

Compound 4, percent growth inhibition at one concentration: 29%
For compound 4 the middle estimate is 1 percentage points below the measured one; the range from low to high includes it.
By their numbers in this assay, from the lowest: compounds 1, 3, 4 and 2 (each within the scatter of the next).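

In this assay, among the compounds shown here, the halogen on the benzyl ring can now be read by itself: fluoro in place of bromo on an aromatic carbon gives (a number 5 percentage points lower from compound 2 to compound 4 (within the scatter)), the first step that changes the halogen and nothing else. The step that changes the halogen and its place together, 3-bromobenzyl to 2-fluorobenzyl, gives (a number 4 percentage points higher from compound 3 to compound 4 (within the scatter)), so neither kind of change on this ring leaves the scatter among the compounds shown. No measurement is available to explain these readings.

On these data alone, only halogens on the benzyl ring are covered here, so an amine or a carboxylic acid on that ring, or a longer chain in place of the benzyl group, remains open. All readings in this assay come from a single concentration, which leaves the dose response of these compounds open as well.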